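A pyridin-2-yl ring replaces a thiazolyl ring on sulfur

This account rests on a few compounds, and the source may have more. Where it says the series, first, only, none or still open, it means among the compounds named here.

Measured so far in a functional assay on PC-3 cells (Homo sapiens) for inhibition, read by MTT assay, with a stated time of 72 h; a higher number here means a weaker inhibitor, a lower number a stronger inhibitor:

- compound 1 `CCN1CCN(c2cc(C(F)(F)F)nc(SCc3ccc(C(F)(F)F)cc3)n2)CC1` gives 27200 nM
- compound 2 `Cc1csc(Sc2cc(C(F)(F)F)nc(SCc3ccc(C(F)(F)F)cc3)n2)n1` gives 12000 nM

Of these two, compound 2 holds the lower number, so it is the stronger inhibitor of the pair. The next molecule, compound 3 `FC(F)(F)c1ccc(CSc2nc(Sc3ccccn3)cc(C(F)(F)F)n2)cc1`, keeps the shared core and changes one group: pyridin-2-yl in place of 4-methyl-1,3-thiazol-2-yl on a sulfur. In words, pyridin-2-yl stands in place of 4-methyl-1,3-thiazol-2-yl on a sulfur.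

Going by the values given here, only one measured step bears on this, and it is modest: a 2.3-fold lower number from compound 1 to compound 2 (0.36 log units; beyond the scatter). That step put (4-methyl-1,3-thiazol-2-yl)sulfanyl in place of 4-ethylpiperazin-1-yl on an aromatic carbon. The new change is a different one, since the sulfur stays and only the aromatic ring on it is exchanged. Among the compounds with values here, no measured pair tests that exchange directly, so no step beyond the scatter is expected in this assay, in either direction. The estimated change is a 1.1-fold higher number from compound 2 to compound 3 (0.03 log units; within the scatter) as an expectation only. For compound 3 the expected value is 13000 nM, with an estimated range from 5500 nM to 30000 nM for the measurement.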

Compound 3, half-maximal inhibitory concentration: 25200 nM
Compound 3: middle estimate off by 1.9-fold (0.29 log units), on the low side, within the range that was stated.
By their numbers in this assay, from the lowest: compound 2; then compounds 3 and 1 (each within the scatter of the next).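

In this assay the ring on the sulfur turns out to matter: pyridin-2-yl in place of 4-methyl-1,3-thiazol-2-yl gives a 2.1-fold higher number from compound 2 to compound 3 (0.32 log units; beyond the scatter), a modest step, even though the two groups have the same number of heavy atoms. The sulfur link alone therefore does not carry the lower number of compound 2, since (pyridin-2-yl)sulfanyl in place of 4-ethylpiperazin-1-yl gives a 1.1-fold lower number from compound 1 to compound 3 (0.03 log units; within the scatter), which leaves compound 1 and compound 3 indistinguishable in this assay. Nothing available explains why the ring exchange has this effect.

The exchange alters the ring size, the hetero atoms and the methyl group all at once, so these three compounds cannot show which of those differences accounts for the step. A plain 1,3-thiazol-2-yl ring without the methyl group, or a pyridin-2-yl ring carrying a methyl group, would help separate them, and a phenyl ring on the same sulfur would show what happens with no hetero atom in the ring at all.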